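The source may report more compounds than this note shows. Statements on the series, on what has been measured and on what is new or still open speak of the compounds shown alone.

Of the compounds shown here, three have so far been measured in an ADME assay on microsomes from liver (Homo sapiens) for metabolic stability, read by LC-MS, using NADPH, with a stated time of 10 min, tested at 0.5 uM (on this read-out lower numbers stand for a less stable compound and higher numbers for a more stable compound), and they lie close together. Compound 3 (`COC(=O)Nc1cc(-c2ccc(OC[C@@](C)(N)CC(C)C)nc2)ccn1`) gives 100% there, and compound 1 (`COC(=O)Nc1cc(-c2cnc(OC[C@@](C)(N)CC(C)C)c(Cl)c2)ccn1`) gives 90% within the scatter of it. Compound 2 (`COC(=O)Nc1cc(-c2ccc(OC[C@@](C)(N)CC(C)C)c(F)c2)ccn1`) gives 82% as its number, lower than compound 3 by more than the scatter but within the scatter of compound 1.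

The unmeasured compound 4 (`COC(=O)Nc1cc(-c2cnc(OC[C@@](C)(N)CC(C)C)c(C#N)c2)ccn1`) differs from compound 3 by a single change, cyano in place of hydrogen on an aromatic carbon, ortho to a (2-amino-2,4-dimethylpentyl)oxy group.

Within the data shown here, one measured step bears on this: a number 10 percentage points higher from compound 1 to compound 3 (within the scatter) on that same carbon, with hydrogen in place of chloro. Read in reverse, it points to a small downward move when a group replaces that hydrogen, though the step itself lies within the scatter. Among the measured compounds shown here, compound 2 has no measured step to guide the comparison, and no measurement yet shows cyano on this core. The estimate is therefore a number 10 percentage points lower from compound 3 to compound 4 (within the scatter) as a downward step that is not expected to exceed the scatter. In this assay the estimated value for compound 4 is 90% with an expected range from 78% to 100% for this estimate.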

Compound 4, percent of the compound remaining: 95%
The estimate for compound 4 lay 5 percentage points below the measured number, and the stated range covers the measured number.
By their numbers in this assay, from the lowest: compounds 2, 1, 4 and 3 (each within the scatter of the next, the first and the last beyond it).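

On the aromatic carbon ortho to the (2-amino-2,4-dimethylpentyl)oxy group and two atoms from the ring nitrogen, three substituents can now be compared in this assay: hydrogen, chloro and cyano. Cyano in place of hydrogen gives a number 5 percentage points lower from compound 3 to compound 4 (within the scatter), and cyano in place of chloro gives a number 5 percentage points higher from compound 1 to compound 4 (within the scatter), so alongside a number 10 percentage points higher from compound 1 to compound 3 (within the scatter), none of the three exchanges at this carbon separates from the others in this read-out, and the nitrile with its triple bond is tolerated here as far as these numbers can show. Nothing available explains why these steps are small.

What the compounds leave open is whether a different kind of group on this same carbon, such as an amine, a carboxylic acid or a longer chain, would give a step beyond the scatter. As far as these compounds go, it is also open whether cyano would give a similar step on the core of compound 2, which has a fluoro group at the corresponding place and whose own number stands apart from that of compound 3.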